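Lengthening the sulfur-linked hydroxy chain of compound 3

The compounds below may be only part of what the source reports. "The series", "measured", "known", "first", "only" and "open" are said of these compounds alone.

In a functional assay on Raji cells (Homo sapiens) for inhibition, read by MTT assay, with a stated time of 96 h (a lower number here means that less compound is needed, a higher number that more compound is needed for the effect), compound 1 (`CC(C)Cn1c(=O)n(C)c(=O)c2c1nc(Cc1cccc3ccccc13)c(=O)n2CCCCO`) gives 150 nM as its half-maximal concentration. Compound 2 (`CC(C)Cn1c(=O)n(C)c(=O)c2c1nc(Cc1cccc3ccccc13)c(=O)n2CCCCCCO`) reads > 10000 nM, which is a limit of the assay and not a number. Within the data shown here, compound 3 (`CC(C)Cn1c(=O)n(C)c(=O)c2nc(SCCO)c(Cc3cccc4ccccc34)nc21`) gives 2850 nM, the higher of the two actual numbers so far.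

Compound 4 (`CC(C)Cn1c(=O)n(C)c(=O)c2nc(SCCCCO)c(Cc3cccc4ccccc34)nc21`) differs from compound 3 by 2-hydroxyethyl in place of hydroxy on a saturated chain carbon, two bonds along the chain from a sulfur. In words, this is 2-hydroxyethyl in place of hydroxy on a saturated chain carbon, two bonds along the chain from a sulfur, turning (2-hydroxyethyl)sulfanyl into (4-hydroxybutyl)sulfanyl.

Among the measured compounds shown here, the one measured step of this kind is an at least 66-fold higher number from compound 1 to compound 2 (1.82 log units; beyond the scatter), for the same swap four bonds along the chain from an aromatic nitrogen. Its size rests on (the limit of > 10000 nM in this assay, at which 1 of the 3 values shown sits). That step argues for a higher number, but it starts from a chain that is already longer. Compound 1 carries a 4-hydroxybutyl group, though on nitrogen and not on sulfur, and its 150 nM points the other way. These two hints offset each other, so no step beyond the scatter is expected in this assay, though the uncertainty is wide.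

The expected change is a 1.1-fold higher number from compound 3 to compound 4 (0.02 log units; within the scatter).

For compound 4 the estimated value is 3000 nM, with an expected range from 500 nM to 10000 nM.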

Compound 4, half-maximal effective concentration: 37 nM
For compound 4 the middle estimate is 81-fold (1.91 log units) above the measured one; the whole stated range lies above it.
By their numbers in this assay, from the lowest: compound 4; then compound 1; then compound 3. At a limit, above all of these: compound 2.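

In this assay, turning (2-hydroxyethyl)sulfanyl into (4-hydroxybutyl)sulfanyl gives a 77-fold lower number from compound 3 to compound 4 (1.89 log units; beyond the scatter), and a lower number here means that less compound is needed, so this longer chain on sulfur is a large gain. The one earlier step of this kind went the other way, which shows that adding the same two chain carbons has no fixed direction here and that the outcome depends on the core and on where the chain sits: the same change on two cores in this assay, an at least 66-fold higher number (1.82 log units; beyond the scatter) from compound 1 to compound 2 and a 77-fold lower number (1.89 log units; beyond the scatter) from compound 3 to compound 4, at least 5100-fold (3.71 log units) apart, beyond the scatter of two such steps Compound 2 gives a limit and not a number, so the gap between these two steps has only a lower bound and its true size stays unknown: the limit of > 10000 nM in this assay, at which 1 of the 4 values shown sits.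

With only two chain lengths shown on sulfur, it remains open whether a longer chain such as 6-hydroxyhexyl would extend the gain or reverse it, as happened on the nitrogen chain. Going by these compounds, it is also open how much the hydroxy end of the chain matters, which a plain butyl chain, a 4-aminobutyl chain or a chain ending in a carboxylic acid on the same sulfur could help to settle.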